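The compounds below may be only part of what the source reports. "The series", "measured", "known", "first", "only" and "open" are said of these compounds alone.

Of the compounds shown here, three built on one shared core have been measured in a functional assay on U2OS cells for antagonist activity at C-X-C chemokine receptor type 3 (Homo sapiens), read by beta-arrestin recruitment; a lower number here means a stronger inhibitor, a higher number a weaker inhibitor. Compound 1 `COc1ccc(-c2nc(C(F)(F)F)sc2N2CCN(C(=O)Cn3cnc4cccnc43)[C@H](C)C2)cc1` gives 131 nM. Compound 2 `COc1ncc(-c2nc(C(F)(F)F)sc2N2CCN(C(=O)Cn3cnc4cccnc43)[C@H](C)C2)cn1` gives 177 nM in this assay, a step of a 1.4-fold higher number from compound 1 to compound 2 (0.13 log units; within the scatter). Compound 3 `CCOc1ncc(-c2nc(C(F)(F)F)sc2N2CCN(C(=O)Cn3cnc4cccnc43)[C@H](C)C2)cn1` gives 20 nM in this assay, the lowest of the three numbers; it is reached by a 6.6-fold lower number from compound 1 to compound 3 (0.82 log units; beyond the scatter) and by an 8.9-fold lower number from compound 2 to compound 3 (0.95 log units; beyond the scatter).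

Compound 4 `CCOc1ncc(-c2nc(C(F)(F)F)sc2N2CCN(C(=O)Cn3c(=O)oc4ccccc43)[C@H](C)C2)cn1` has not yet been measured. It differs from compound 3 in that (a group of 10 heavy atoms (7 carbon, 1 nitrogen, 2 oxygen; one five-membered aromatic ring with 2 hetero atoms, one six-membered aromatic ring of carbon only) in place of a group of 9 heavy atoms (6 carbon, 3 nitrogen; one five-membered aromatic ring with 2 hetero atoms, one six-membered aromatic ring with 1 hetero atom), on a saturated chain carbon bound to a carbonyl carbon). None of the three measured steps bears on this part of the core: each of them alters the aromatic ring at the far end of the shared core or the alkoxy chain on it, while the group on the saturated chain carbon bound to the carbonyl carbon is the same in compounds 1, 2 and 3. Going by the values given here, there is thus no measured step from which the size or direction of this change can be read, and the expectation must stay wide. Compound 4 is expected to give 60 nM in this assay, with a range from 12 nM to 400 nM. The step expected from compound 3 to compound 4 is a 3.0-fold higher number from compound 3 to compound 4 (0.48 log units; beyond the scatter), a guess of a moderate loss that carries large uncertainty in both directions.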

Compound 4, half-maximal inhibitory concentration: 99 nM
Compound 4: the middle estimate sits 1.7-fold (0.22 log units) below what was measured; measured number inside the range.
By their numbers in this assay, from the lowest: compound 3; then compounds 4, 1 and 2 (each within the scatter of the next).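

In this assay, going by these compounds alone, the group on a saturated chain carbon bound to a carbonyl carbon is varied for the first time, and the exchange gives a 5.0-fold higher number from compound 3 to compound 4 (0.69 log units; beyond the scatter), so the reading depends on this position as well as on the far end of the shared core. The step appears even though the counts of hydrogen-bond donors and acceptors stay the same, and compound 4 still gives 99 nM with a six-membered aromatic ring of carbon only and a double bond outside aromatic rings in the new group. No measurement offered here accounts for the step.

The ring atoms and the added double bond change together, so the compounds shown do not separate their contributions. Also open, from the compounds shown here alone, is how an open-chain group, such as a dimethylamino or a morpholine, would read at this place.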